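From Benzoyl to Isopropylsulfonyl on the Amine Nitrogen

This account rests on a few compounds, and the source may have more. Where it says the series, first, only, none or still open, it means among the compounds named here.

Compound 1, `COc1ccc(-n2c(C)nc3c(N4CC[C@@H](NC(C)=O)C4)nc(C)nc32)cc1OC`, gives only a limit, > 95%, in an ADME assay on microsomes from liver (Mus musculus) for metabolic stability, read by LC-MS, with NADPH named in the record, with a stated time of 60 min, tested at 1 uM, in the absence of a further agent; a higher number here means that more of the compound is left, a lower number that less of the compound is left.
Compound 2, `CC(=O)N[C@@H]1CCN(c2cc(C)nn3c(-c4cccs4)c(C)nc23)C1`, likewise gives only a limit, > 95%, in this assay.
Compound 3, `COc1ccc(-c2c(C)nc3c(N4CC[C@@H](NC(=O)c5ccccc5)C4)cc(C)nn23)cc1OC`, also gives only a limit, > 95%, in this assay.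

Compound 3 therefore stands where the other two stand: at a limit of this assay, and no number separates it from them. No pair among these three differs in a single place, so no measured step is at hand.

Compound 4, `COc1ccc(-c2c(C)nc3c(N4CC[C@@H](NS(=O)(=O)C(C)C)C4)cc(C)nn23)cc1OC`, differs from compound 3 in one place: isopropylsulfonyl in place of benzoyl on an amine nitrogen. Since all three measured compounds sit at the same limit (the limit of > 95% in this assay, at which 3 of the 3 values shown sit), compound 4 is expected to remain there, with the step of a number no higher from compound 3 to compound 4 (the limit leaves the size open) expected to lie within the scatter. Compound 4 is thus estimated at 95% in this assay, between 85% and 100%.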

Compound 4, percent of the compound remaining: > 95%
Compound 4: only a limit was reported; the forecaster's own chance of this, stated with the estimate: 75%; the middle value sits exactly at the limit.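

No new step can be read: compound 3 and compound 4 are both reported only as limits in this assay, so the change between them has no readable size. The compounds shown leave open how far they differ from one another, because all of them sit at one limit: the limit of > 95% in this assay, at which 4 of the 4 values shown sit.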